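A few compounds are considered here, and "the series" means these few. Any claim that something is new, unique, unknown or untested is made for them only; others in the source may bear on it.

Of the compounds shown here, three sharing one core have been measured in an ADME assay on RAW264.7 cells (Mus musculus) for cytotoxicity, read by MTT assay, with a stated time of 72 h, tested at 50 ug/mL; on this read-out higher numbers stand for more inhibition at the one concentration tested (going by the name of the read-out) and lower numbers for less inhibition. Compound 1 `CN1CCN(C(=O)c2nc3ccccc3s2)CC1` gives 52.1%. Compound 2 `CN1CCN(C(=O)c2nc3cc(C(F)(F)F)ccc3s2)CC1`, which carries a trifluoromethyl group, gives 12.6%, and compound 3 `CCOC(=O)c1nc2cc(C(F)(F)F)ccc2s1` gives 29.1%. Among these three numbers compound 2 stands lowest, and both of its neighbours lie beyond the scatter: putting trifluoromethyl in place of hydrogen on an aromatic carbon gave a number 39.5 percentage points lower from compound 1 to compound 2 (beyond the scatter), while putting ethoxy in place of 4-methylpiperazin-1-yl on the carbonyl carbon gave a number 16.5 percentage points higher from compound 2 to compound 3 (beyond the scatter).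

Compound 4 `O=C(c1nc2cc(C(F)(F)F)ccc2s1)N1CCN(c2ccncc2)CC1` has not yet been measured. It differs from compound 2 in a single place: pyridin-4-yl in place of methyl on an amine nitrogen in a ring. Neither measured step touches this place. The first step changes the aromatic part of the core, and the second removes the whole six-membered ring that carries the amine nitrogen. Both show that one change on this core can move the read-out beyond the scatter, yet neither points in a direction for a swap on the amine nitrogen in the ring. The step from compound 2 to compound 4 is therefore expected to be small, a number 7.4 percentage points higher from compound 2 to compound 4 (within the scatter), with its direction open. For compound 4 in this assay the estimated value is 20%, within a range from 5% to 40%.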

Compound 4, a percentage reported as inhibition, at one concentration (the size of the read-out at that concentration, not a potency): 17.5%
Compound 4: middle estimate off by 2.5 percentage points, on the high side, within the range that was stated.
By their numbers in this assay, from the lowest: compounds 2 and 4 (each within the scatter of the next); then compound 3; then compound 1.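

In this assay, putting pyridin-4-yl in place of methyl on the amine nitrogen in the ring gave a number 4.9 percentage points higher from compound 2 to compound 4 (within the scatter), so this exchange of a single carbon for a six-membered aromatic ring with an added hydrogen-bond acceptor leaves the two compounds indistinguishable on this read-out. The earlier steps shown here showed that a change on the aromatic part of the core or at the carbonyl can shift the number beyond the scatter, whereas this first change on the amine nitrogen shows that a much larger group can be carried there without any shift that can be told from the scatter. No measurement shown here explains why the read-out stays put under this swap.

One swap says little about the amine nitrogen as a whole: a hydrogen, a longer chain or a group bearing a carboxylic acid could behave differently there. As far as these compounds go, it also stays open whether pyridin-4-yl would act the same way on the core of compound 1, which lacks trifluoromethyl and has the highest number of the series.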